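The source may hold more compounds than are shown below. What is called first, only, known or untested is meant among the compounds shown, and "the series" means these compounds.

Compound 1 `COc1ccccc1/C=C/C(=O)c1ccc(OCC(=O)N[C@H]2CCOC2=O)cc1` gives > 64000 nM in a functional assay on MCF7 cells (Homo sapiens) for antiproliferative activity, read by MTT assay, with a stated time of 72 h; on this read-out higher numbers stand for weaker inhibition and lower numbers for stronger inhibition; this is a limit of the assay, not a number.
Compound 2 `CC(C)c1ccc(/C=C/C(=O)c2ccc(OCC(=O)N[C@H]3CCOC3=O)cc2)cc1` gives 23400 nM in this assay.

Compound 2 holds the one numerical result shown in this assay. Among the measured compounds shown here, the other value, that of compound 1, is a limit of > 64000 nM in this assay, at which 1 of the 2 values shown sits, and says only that its number lies past the range of the assay.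

Compound 3 `O=C(COc1ccc(C(=O)/C=C/c2ccccc2)cc1)N[C@H]1CCOC1=O` differs from compound 2 by hydrogen in place of isopropyl on an aromatic carbon. For the measured compounds named here, the single measured step, an at least 2.7-fold lower number from compound 1 to compound 2 (0.43 log units; beyond the scatter), changes two things at once, the ring position and the kind of substituent, so it does not isolate the isopropyl on its own. It does show that altering the substituent on that ring can shift the number by a modest amount, and that the values here sit near the limit of the assay (the limit of > 64000 nM in this assay, at which 1 of the 2 values shown sits). Taking the isopropyl away is expected to weaken inhibition somewhat, estimated as a 1.7-fold higher number from compound 2 to compound 3 (0.23 log units; within the scatter). Compound 3 is therefore estimated at 40000 nM in this assay, with a likely range from 15000 nM to 100000 nM.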

Compound 3, half-maximal inhibitory concentration: > 64000 nM
Compound 3: only a limit was reported; the forecaster's own chance of this, stated with the estimate: 35%; middle value at least 1.6-fold (0.20 log units) away from the limit.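

Replacing the isopropyl with hydrogen is a change in one place only, on an aromatic carbon para to a large group, and it gives an at least 2.7-fold higher number from compound 2 to compound 3 (0.43 log units; beyond the scatter) in this assay. Unlike the earlier step from the 2-methoxyphenyl, which changed both the ring position and the kind of substituent, this one ties the stronger inhibition of compound 2 to the 4-isopropylphenyl itself, although the value of compound 3 is a limit and not a number, so the step gives only a minimum size. The step between compound 1 and compound 3 cannot be read, as both values are limits, and compound 2 alone now holds a number on this read-out: the limit of > 64000 nM in this assay, at which 2 of the 3 values shown sit.

As far as these compounds go, what remains open is whether isopropyl is special here or whether other groups at this place would also bring the number down into the readable range. From the compounds shown here alone, a methyl, a longer chain such as butyl, an amine or a carboxylic acid at the same place on the ring would begin to answer this, and the true distance between the plain phenyl and the 4-isopropylphenyl also stays unknown.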